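Dropping one fluorine from a difluorobenzyl side chain

The source may hold more compounds than are shown below. What is called first, only, known or untested is meant among the compounds shown, and "the series" means these compounds.

Measured so far:
compound 1, `CN1CCC[C@@H]1Cn1nc(Cc2ccc(F)c(F)c2)c2ccccc2c1=O`: 316 nM
compound 2, `CN1CCC[C@@H]1Cn1nc(Cc2ccc(C(C)(C)C)cc2)c2ccccc2c1=O`: > 1990 nM
compound 3, `O=c1c2ccccc2c(Cc2ccc(Cl)cc2)nn1C[C@H]1CCCN1CCCCCc1ccc(OCCCN2CCCCCC2)cc1`: 50.1 nM

Of the compounds shown here, three sharing one core have been tested in an assay for binding affinity to Alpha-1B adrenergic receptor (Homo sapiens); on this read-out higher numbers stand for weaker inhibition and lower numbers for stronger inhibition. Compound 1 gives 316 nM in this assay, the higher of the two numbers reported. Compound 3, which carries a long chain on the ring nitrogen in place of the small methyl group, gives 50.1 nM in this assay, a gap from compound 1 that lies beyond the usual scatter. For compound 2 this assay reports only a limit, (the limit of > 1990 nM in this assay, at which 1 of the 3 values shown sits), so no number stands for it.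

Compound 4, `CN1CCC[C@@H]1Cn1nc(Cc2cccc(F)c2)c2ccccc2c1=O`, is not yet measured. It differs from compound 1 by hydrogen in place of fluoro on an aromatic carbon. Going by the values given here, no measured pair in this set differs by such a single step, so the size of the change can only be guessed. The loss of one small group from the benzyl ring is expected to move the number little, if at all, with a slight lean toward a higher value; the step from compound 1 to compound 4 is estimated at a 1.3-fold higher number from compound 1 to compound 4 (0.10 log units; within the scatter), which is within the scatter. Compound 4 is therefore expected to give about 400 nM in this assay, between 150 nM and 1200 nM.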

Compound 4, inhibition constant: 398 nM
Estimate against measurement, compound 4: 1.0-fold (0.00 log units) above, within the range that was stated.
By their numbers in this assay, from the lowest: compound 3; then compounds 1 and 4 (each within the scatter of the next). At a limit, above all of these: compound 2.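

In this assay, the step of a 1.3-fold higher number from compound 1 to compound 4 (0.10 log units; within the scatter) comes with hydrogen in place of fluoro on an aromatic carbon, at the place ortho to a fluoro group and para to a large group. Going by these compounds alone, this is the first single-place step in the set, and it shows that, in going from 3,4-difluorobenzyl to 3-fluorobenzyl, this fluoro group can be replaced by hydrogen without a change that stands out from the scatter, so on this read-out the two side chains cannot be told apart. The one limit on hand belongs to another compound and does not bear on this step, so nothing here speaks to a cause.

Open, from the compounds shown here alone, is whether a methoxy group, a nitrile or an amine at this same place would leave the number as undisturbed as hydrogen does, and whether removing the remaining fluoro group as well, to leave an unsubstituted benzyl, would do so too. Also open, going by these compounds, is whether the same change would read alike on a compound carrying a longer chain on the ring nitrogen, as compound 3 does.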